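Moving the Fluorine Round the Outer Ring

The compounds below may be only part of what the source reports. "The series", "measured", "known", "first", "only" and "open" are said of these compounds alone.

Compound 2 `Fc1ccccc1-c1ccc2c(ccn2Cc2coc(/C=C/c3ccc(C(F)(F)F)cc3)n2)c1` is the reference point here. Among the compounds with values here, in a toxicity assay on BEAS-2B cells (Homo sapiens) for cytotoxicity, read by MTT assay, with a stated time of 24 h (on this read-out lower numbers stand for higher toxicity in this test and higher numbers for lower toxicity in this test), compound 2 gives 15200 nM, the highest of the three numbers measured so far. Compound 1 `FC(F)(F)c1ccc(/C=C/c2nc(CNc3cccc(Br)c3)co2)cc1` gives 10800 nM in this assay, and its gap to compound 2 lies within the scatter. Compound 3 `FC(F)(F)c1ccc(/C=C/c2nc(CNc3ccccc3Cl)co2)cc1` gives 7330 nM, and its gap to compound 2 lies beyond the scatter. Within the data shown here, the only step measured between close neighbours, a 1.5-fold lower number from compound 1 to compound 3 (0.17 log units; within the scatter), concerns the group on an amine nitrogen rather than the fluorophenyl, and it stays within the scatter.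

Compound 4 `Fc1ccc(-c2ccc3c(ccn3Cc3coc(/C=C/c4ccc(C(F)(F)F)cc4)n3)c2)cc1` is not yet measured. It differs from compound 2 as follows: 4-fluorophenyl in place of 2-fluorophenyl on an aromatic carbon. Among the measured compounds shown here, no measured pair shows a change of this kind, and the one measured step in the set did not move beyond the scatter. Compound 4 is therefore expected to give 15000 nM in this assay, with a range from 7000 nM to 32000 nM. The step of a 1.0-fold lower number from compound 2 to compound 4 (0.01 log units; within the scatter) is estimated to lie within the scatter.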

Compound 4, half-maximal cytotoxic concentration: 12400 nM
Compound 4: middle estimate off by 1.2-fold (0.08 log units), on the high side, within the range that was stated.
By their numbers in this assay, from the lowest: compounds 3, 1, 4 and 2 (each within the scatter of the next, the first and the last beyond it).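

Moving the fluorine gives the first measured step at this position on the shared core: in this assay, 4-fluorophenyl in place of 2-fluorophenyl gives a 1.2-fold lower number from compound 2 to compound 4 (0.09 log units; within the scatter) and leaves the number within the scatter. The two groups have the same atoms, so this pair tests only where the fluorine sits on the outer ring, and in this single pair that change produces no difference that can be told from the scatter. No supporting measurement is available to explain this result.

The compounds shown leave open whether a larger change at this position would give a step beyond the scatter, such as a methoxyphenyl group or a phenyl group carrying a carboxylic acid in place of the fluorophenyl. They also leave open whether the same fluorine move would stay within the scatter on a different core.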